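Removing the allyloxy group from a cyclopentenone scaffold

The source may hold more compounds than are shown below. What is called first, only, known or untested is meant among the compounds shown, and "the series" means these compounds.

Measured compounds:
compound 1, `COc1ccc(C2=C(c3cc(OC)c(OC)c(OC)c3)C(=O)CC2O[SiH2]C(C)(C)C)cc1OC`: > 100 ug/mL
compound 2, `C=CCOc1cc(C2=C(c3cc(OC)c(OC)c(OC)c3)C(=O)C(O)C2)ccc1OC`: > 100 ug/mL

In an ADME assay on HEp-2 cells (Homo sapiens) for cytotoxicity, read by MTT assay, with a stated time of 72 h (a lower number here means a stronger inhibitor, a higher number a weaker inhibitor), compound 1 returns only a limit, > 100 ug/mL. Compound 2 likewise returns only a limit in this assay, > 100 ug/mL. Among the measured compounds shown here, neither value is a number, and no step between measured compounds can be stated; the evidence is simply (the limit of > 100 ug/mL in this assay, at which 2 of the 2 values shown sit). Compound 3, `COc1ccc(C2=C(c3cc(OC)c(OC)c(OC)c3)C(=O)C(O)C2)cc1`, remains to be measured. It differs from compound 2 by hydrogen in place of allyloxy on an aromatic carbon. With both measured compounds sitting at the limit, there is no basis for expecting a step beyond the scatter in either direction, so the step from compound 2 to compound 3 is expected to be a step that the limit leaves unreadable from compound 2 to compound 3. Compound 3 is therefore estimated at 150 ug/mL, within a range from 60 ug/mL to 400 ug/mL, and most likely to be reported again as a limit.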

Compound 3, half-maximal inhibitory concentration: < 1 ug/mL
Compound 3 gave a limit, no number; the forecaster's own chance of this, stated with the estimate: 80%; middle value at least 150-fold (2.17 log units) away from the limit.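

In this assay, the aromatic carbon ortho to a methoxy group and meta to a large group proves to be a place where a single change can be read: hydrogen in place of allyloxy gives an at least 100-fold lower number from compound 2 to compound 3 (2.00 log units; beyond the scatter). The earlier compounds shown here both sat at one limit and offered no readable step, so they could not show that this scaffold can register in the assay at all. Compound 3 gives < 1 ug/mL, which is a limit and not a number, so the step has a minimum size but no known true size.

The compounds shown leave open how far the value of compound 3 lies beyond its limit. They also leave open whether a hydroxyl group, an amine or a propyloxy chain on this carbon would behave like hydrogen or like allyloxy.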